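The compounds below may be only part of what the source reports. "The series", "measured", "known", "first", "only" and "open" are said of these compounds alone.

Measured in a functional assay on HEK293 cells for agonist activity at Bile acid receptor (Homo sapiens); a lower number here means a smaller maximal response, a higher number a larger maximal response:
Compound 1, `CC(C)c1onc(-c2c(Cl)cccc2Cl)c1COc1ccc(N(C)Cc2ccc(OCC(=O)O)cc2)c(C(F)(F)F)n1`: 69%
Compound 2, `CC(Nc1ccc(C(=O)O)cc1)c1ccc(OCc2c(-c3c(Cl)cccc3Cl)noc2C2CC2)nc1C(F)(F)F`: 59%
Compound 3, `CC(c1ccc(OCc2c(-c3c(Cl)cccc3Cl)noc2C2CC2)nc1C(F)(F)F)N(C)c1ccc(C(=O)O)cc1`: 55%

Compound 2 stands second highest of these three numbers in this assay, yet neither neighbour is separated from it beyond the scatter: compound 3 lies a number 4 percentage points lower from compound 2 to compound 3 (within the scatter) away, and compound 1 sits higher only by an amount that the scatter covers. The unmeasured compound 4, `O=C(O)c1ccc(OCc2ccc(OCc3c(-c4c(Cl)cccc4Cl)noc3C3CC3)nc2C(F)(F)F)cc1`, differs from compound 2 in one place: (4-carboxyphenoxy)methyl in place of 1-((4-carboxyphenyl)amino)ethyl on an aromatic carbon. Going by the values given here, only one step between measured compounds is available, the change from compound 2 to compound 3, a methyl in place of hydrogen on a nitrogen on an aromatic ring, which moved this assay by a number 4 percentage points lower from compound 2 to compound 3 (within the scatter). That step touches a different part of the molecule and cannot be carried over directly; compounds 1 and 2 differ in several places at once, so their two values show only that this series moves little. No step beyond the scatter is therefore expected from compound 2 to compound 4, with a number 2 percentage points lower from compound 2 to compound 4 (within the scatter) as the expected shift. For compound 4 an efficacy of 57% is estimated, in the range 40% to 74%.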

Compound 4, largest response reached (reported as efficacy), in percent of the reference or control that the assay uses: 59%
Compound 4: middle estimate off by 2 percentage points, on the low side, and the stated range covers the measured number.
By their numbers in this assay, from the lowest: compounds 3, 2, 4 and 1 (each within the scatter of the next, the first and the last beyond it).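

In this assay, the exchange at the aromatic carbon ortho to a trifluoromethyl group gave no change at the digits printed from compound 2 to compound 4 (within the scatter). The earlier step, a number 4 percentage points lower from compound 2 to compound 3 (within the scatter), only added a methyl to the nitrogen, whereas this one removes that nitrogen altogether: (4-carboxyphenoxy)methyl, which has none, takes the place of 1-((4-carboxyphenyl)amino)ethyl, so in these two compounds the maximal response does not depend on a nitrogen in this chain. No supporting data bear on why the response stays level.

The compounds shown leave open whether this position would keep the same response with a longer chain before the benzene ring, or with an amide in place of the carboxylic acid. They also leave open whether the two linking chains would match in anything other than the largest response reached.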